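The source may report more compounds than this note shows. Statements on the series, on what has been measured and on what is new or still open speak of the compounds shown alone.

Compound 2 `CC(C)N(C(=O)CCNC(=O)c1ccc(S(C)(=O)=O)c([N+](=O)[O-])c1)C(C)C` is known in an assay on isolated protein for inhibition of vitamin D3 receptor (Homo sapiens), read by fluorescence polarization (a lower number here means a stronger inhibitor, a higher number a weaker inhibitor), only as a limit: compound 2 gives > 60000 nM. Compound 1 `CC1CCN(C(=O)CCNC(=O)c2ccc(S(C)(=O)=O)c([N+](=O)[O-])c2)CC1` also reaches only a limit, giving > 60000 nM in this assay. The step that the two limits leave unreadable from compound 1 to compound 2 stays unreadable because both values sit at the limit of > 60000 nM in this assay, at which 2 of the 2 values shown sit. Compound 3 `CS(=O)(=O)c1ccc(C(=O)NCCC(=O)N2CCc3ccccc3C2)cc1[N+](=O)[O-]` differs from compound 2 by 1,2,3,4-tetrahydroisoquinolin-2-yl in place of diisopropylamino on a carbonyl carbon. Among the compounds with values here, no measured step here has a readable size, so no shift beyond the usual scatter is expected, and the change a number no higher from compound 2 to compound 3 (the limit leaves the size open) is taken as the estimate. Compound 3 is therefore expected at 60000 nM, with a range from 15000 nM to 120000 nM.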

Compound 3, half-maximal inhibitory concentration: > 60000 nM
Compound 3 was reported as a limit; the forecaster's own chance of this, stated with the estimate: 85%; the middle value lies on the limit itself.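

The steps among compound 1, compound 2 and compound 3 cannot be read, because all three values are limits: the limit of > 60000 nM in this assay, at which 3 of the 3 values shown sit.

These compounds leave open whether any group on this carbonyl carbon changes the strength of inhibition in this assay at all.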